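From 2-iodophenyl to ethyl on the ester carbonyl

A few compounds are considered here, and "the series" means these few. Any claim that something is new, unique, unknown or untested is made for them only; others in the source may bear on it.

Compound 1 `O=C(OC1(C(=O)Nc2ccc([N+](=O)[O-])cc2)CCCCC1)c1ccccc1I` gives the highest of the three numbers in an ADME assay on WI-38 cells (Homo sapiens) for inhibition, read by MTT assay, with a stated time of 72 h (on this read-out higher numbers stand for weaker inhibition and lower numbers for stronger inhibition), at 396 nM. Compound 2 `O=C(OC1(C(=O)Nc2ccc([N+](=O)[O-])cc2)CCCCC1)c1ccccc1` gives 246 nM, and compound 3 `O=COC1(C(=O)Nc2ccc([N+](=O)[O-])cc2)CCCCC1` gives 46.3 nM. Compound 4 `CCC(=O)OC1(C(=O)Nc2ccc([N+](=O)[O-])cc2)CCCCC1` differs from compound 1 by ethyl in place of 2-iodophenyl on a carbonyl carbon. Among the compounds with values here, two measured steps bear on this change: an 8.6-fold lower number from compound 1 to compound 3 (0.93 log units; beyond the scatter) and a 5.3-fold lower number from compound 2 to compound 3 (0.73 log units; beyond the scatter), each putting hydrogen in place of an aryl on the carbonyl carbon, whereas a 1.6-fold lower number from compound 1 to compound 2 (0.21 log units; within the scatter). Ethyl is neither hydrogen nor 2-iodophenyl, so a lower number than for compound 1 is expected, likely short of the size seen for compound 3. The expected step is a 4.0-fold lower number from compound 1 to compound 4 (0.60 log units; beyond the scatter). Compound 4 is therefore estimated at 100 nM, with a range of 40 nM to 250 nM.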

Compound 4, half-maximal inhibitory concentration: 44.6 nM
Compound 4: middle estimate off by 2.2-fold (0.35 log units), on the high side; the measured number falls inside the stated range.
By their numbers in this assay, from the lowest: compounds 4 and 3 (each within the scatter of the next); then compounds 2 and 1 (each within the scatter of the next).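

In this assay, hydrogen is not needed for the drop seen on leaving the aryl groups: ethyl on the carbonyl carbon gives an 8.9-fold lower number from compound 1 to compound 4 (0.95 log units; beyond the scatter) and a 5.5-fold lower number from compound 2 to compound 4 (0.74 log units; beyond the scatter). Ethyl and hydrogen cannot be told apart at this position, with a 1.0-fold lower number from compound 3 to compound 4 (0.02 log units; within the scatter). Nothing shown here accounts for this result.

The compounds shown leave open whether a longer chain such as hexyl, or an amine on the carbonyl carbon, would stay level with compound 3 and compound 4. They also leave open where between ethyl and phenyl the number would begin to rise, for instance with cyclohexyl.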